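Carbamate aryl swap on the shared core

This account rests on a few compounds, and the source may have more. Where it says the series, first, only, none or still open, it means among the compounds named here.

Compound 1 `CC(C)=CCC/C(C)=C/CC1Cc2c(O)cc(=O)n(CCCO)c2CC1(C)C` carries a free hydroxyl on its aromatic ring and in a functional assay on PANC-1 cells (Homo sapiens) for inhibition, read by MTT assay, with a stated time of 24 h, tested at 10 uM (a higher number here means more inhibition at the concentration tested (going by the name of the read-out), a lower number less inhibition), compound 1 gives 0%. Compound 2 `CC(C)=CCC/C(C)=C/CC1Cc2c(OC(=O)Nc3ccc(F)cc3F)cc(=O)n(CCCO)c2CC1(C)C`, bearing the (2,4-difluorophenyl)carbamoyl on that oxygen, gives 15.6% in this assay. Within the data shown here, the one measured step, a number 15.6 percentage points higher from compound 1 to compound 2 (beyond the scatter), is the only movement so far. Compound 2 thus stands highest of the two numbers, with compound 1 as the nearest and beyond the scatter lower.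

Compound 3 `CC(C)=CCC/C(C)=C/CC1Cc2c(OC(=O)Nc3ccc(F)c(Cl)c3)cc(=O)n(CCCO)c2CC1(C)C` keeps the carbamate and changes only the aryl on the amide-type nitrogen: 3-chloro-4-fluorophenyl in place of 2,4-difluorophenyl on an amide-type nitrogen. The step from compound 1 to compound 2 concerns the presence of the whole carbamoyl group, not the halogen pattern on its phenyl, so it bears on compound 3 only indirectly, showing that the carbamate as such carries a modest gain. Among the measured compounds shown here, no measured step speaks to exchanging one dihalophenyl for another.

The expectation is therefore a step within the scatter, a number 1.4 percentage points higher from compound 2 to compound 3 (within the scatter), with compound 3 estimated at 17%, in the range 2% to 38%.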

Compound 3, a percentage reported as inhibition, at one concentration (the size of the read-out at that concentration, not a potency): 0%
Estimate against measurement, compound 3: 17 percentage points above; the measured number lies below the stated range.
By their numbers in this assay, from the lowest: compounds 1 and 3 (each within the scatter of the next); then compound 2.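

In this assay the aryl on the amide-type nitrogen decides the outcome: with 3-chloro-4-fluorophenyl in place of 2,4-difluorophenyl, the series shows a number 15.6 percentage points lower from compound 2 to compound 3 (beyond the scatter). The free hydroxyl and the (3-chloro-4-fluorophenyl)carbamoyl on that oxygen cannot be told apart, with no change at the digits printed from compound 1 to compound 3 (within the scatter), so the modest gain belongs to compound 2 with its particular aryl and not to the carbamate as such. Nothing available explains this dependence on the aryl group.

From the compounds shown here alone, the two aryl groups differ in more than one halogen, so it remains open whether the loss follows the entry of chlorine or the departure of the 2,4-difluoro pattern. Also open, going by these compounds, is how the shared core reads with a plain phenyl, a 4-fluorophenyl or a 2,4-dichlorophenyl on the same nitrogen, or with a morpholine-4-carbonyl in place of the whole arylcarbamoyl group on the oxygen.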